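Chain-end exchange on compound 1: working notes

This account rests on a few compounds, and the source may have more. Where it says the series, first, only, none or still open, it means among the compounds named here.

Measured in a physicochemical assay for lipophilicity, read by LC-MS, using the shake flask method, in phosphate buffer, with a stated time of 50 min, at pH 7.4; a higher number here means a more lipophilic compound, a lower number a more polar compound:
- compound 1 `COCC(=O)NCCCCCC(=O)N[C@H](C(=O)N1C[C@H](O)C[C@H]1C(=O)NCc1ccc(-c2scnc2C)cc1)C(C)(C)C` gives 2.2
- compound 2 `Cc1ncsc1-c1ccc(CNC(=O)[C@@H]2C[C@@H](O)CN2C(=O)[C@@H](NC(=O)CCCCCOC(=O)CC(c2ccccc2)c2ccccc2)C(C)(C)C)cc1` gives 1.9

Only these two numbers are available, and they lie within the scatter of each other. Compound 1 therefore stands level with compound 2 and neither can be ranked.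

Compound 3 `Cc1ncsc1-c1ccc(CNC(=O)[C@@H]2C[C@@H](O)CN2C(=O)[C@@H](NC(=O)CCCCCOC(=O)C2CCCCC2)C(C)(C)C)cc1` has not yet been measured. Its difference from compound 1 lies on a saturated chain carbon, five bonds along the chain from a carbonyl carbon ((cyclohexylcarbonyl)oxy in place of ((methoxymethyl)carbonyl)amino on a saturated chain carbon, five bonds along the chain from a carbonyl carbon). Going by the values given here, no measured step covers this exchange, so any expectation is a judgement from the structures and the two values.

The entering group brings a six-membered non-aromatic ring of carbon only, and a higher reading in this assay is expected on that basis. The expectation stays modest, since the chain of compound 2 (1.9) also joins its carbonyl through oxygen, and that compound shows no separation from compound 1 (2.2). The estimated change is a moderate rise (a number 0.50 log units higher from compound 1 to compound 3 (beyond the scatter)) with wide uncertainty. Compound 3 is estimated at (2.7), with an expected range (2 to 3.4).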

Compound 3, distribution coefficient: 1.1
For compound 3 the middle estimate is 1.60 log units above the measured one, outside the stated range (below it).
By their numbers in this assay, from the lowest: compound 3; then compounds 2 and 1 (each within the scatter of the next).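

In this assay, placing (cyclohexylcarbonyl)oxy in place of ((methoxymethyl)carbonyl)amino on a saturated chain carbon, five bonds along the chain from a carbonyl carbon, gives a number 1.10 log units lower from compound 1 to compound 3 (beyond the scatter) and so provides the first difference at this position that stands clear of the scatter. The direction shows that, for this pair, a larger count of carbon atoms, a six-membered non-aromatic ring of carbon only and the loss of the hydrogen-bond donor do not go with a higher reading. The chains of compound 2 and compound 3 both join their carbonyl through oxygen, yet compound 2 gives 1.9 and compound 3 gives 1.1 with that same link, so the oxygen link alone does not set the reading here.

As far as these compounds go, this exchange alters the linking atom and the end group together, so their shares of the step remain open, and a (cyclohexylcarbonyl)amino group or a chain-end amine or carboxylic acid at this place could help separate them. No accompanying evidence bears on this result, and its origin remains unassigned.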